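From methoxy to ethoxy on a shared core

A few compounds are considered here, and "the series" means these few. Any claim that something is new, unique, unknown or untested is made for them only; others in the source may bear on it.

Compound 1 `CC(=O)Oc1c(C)cc(Cl)c2c1C(=O)C=CC2=O` gives 21800 nM
Compound 2 `COc1cc(C)c(Cl)c2c1C(=O)C=CC2=O` gives 19100 nM
Compound 3 `Cc1cc(O)c2c(c1Br)C(=O)C=CC2=O` gives 11300 nM

In a functional assay on HeLa cells (Homo sapiens) for cytotoxicity, read by XTT assay, with a stated time of 24 h (a higher number here means a weaker inhibitor, a lower number a stronger inhibitor), compound 2 gives 19100 nM and so stands within the usual scatter of both compound 1 and compound 3. Compound 4 `CCOc1cc(C)c(Cl)c2c1C(=O)C=CC2=O` has yet to be measured. The change from compound 2 is methyl in place of hydrogen on a saturated chain carbon bound to an oxygen on an aromatic ring and amounts to methyl in place of hydrogen on a saturated chain carbon bound to an oxygen on an aromatic ring, turning methoxy to ethoxy. Among the measured compounds shown here, no measured pair shows this change, so the only guide is compound 2 at 19100 nM and no shift beyond the scatter is expected. The expected move is a 1.1-fold lower number from compound 2 to compound 4 (0.05 log units; within the scatter) and stays within the scatter. Compound 4 is estimated at 17000 nM with an expected range from 8000 nM to 35000 nM in this assay once it is measured.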

Compound 4, half-maximal inhibitory concentration: 19000 nM
For compound 4 the middle estimate is 1.1-fold (0.05 log units) below the measured one; low and high end bracket the measured number.
By their numbers in this assay, from the lowest: compounds 3, 4, 2 and 1 (each within the scatter of the next).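

In this assay, the change from methoxy to ethoxy gives a 1.0-fold lower number from compound 2 to compound 4 (0.00 log units; within the scatter), and this is the only pair shown that differs in one place. At this position, on a saturated chain carbon bound to an oxygen on an aromatic ring, methyl in place of hydrogen therefore leaves the number within the scatter. No supporting data are available to explain this result.

As far as these compounds go, whether a longer chain such as propyl, or a phenyl ring, on this oxygen would also stay within the scatter remains open. So does the outcome of an amine in place of the ethoxy group on the shared core.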